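This account rests on a few compounds, and the source may have more. Where it says the series, first, only, none or still open, it means among the compounds named here.

Three measured compounds share a single core: compound 1 `O=C(/C=C/c1cccnc1)NCCCCCCc1ccc(S(=O)(=O)Nc2ccccc2)cc1`, compound 2 `O=C(/C=C/c1cccnc1)NCCCCCCCc1cccc(S(=O)(=O)Nc2ccccc2)c1` and compound 3 `Cc1ccc(NS(=O)(=O)c2cccc(CCCCCCNC(=O)/C=C/c3cccnc3)c2)cc1`. In a functional assay on Huh-7 cells (Homo sapiens) for inhibition, read by CCK-8 assay, with a stated time of 72 h (a lower number here means a stronger inhibitor, a higher number a weaker inhibitor), compound 1 gives 112 nM, compound 2 gives 138 nM, and compound 3 gives 6.92 nM. Compound 3 thus holds the lowest number of the three; its nearest neighbour is compound 1 and its furthest is compound 2, and both gaps lie beyond the usual scatter, so compound 3 counts as the strongest inhibitor among them.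

The next compound, compound 4 `O=C(/C=C/c1cccnc1)NCCCCCCc1cccc(S(=O)(=O)Nc2ccc(C(F)(F)F)cc2)c1`, has not yet been measured. It differs from compound 3 in one place: trifluoromethyl in place of methyl on an aromatic carbon. Among the measured compounds shown here, no measured pair shows this same exchange, so no step can be read directly from the numbers. The expectation for this assay is therefore cautious: a small step, if any, most likely a mild loss that need not exceed the scatter, and the change is expected to be a 1.6-fold higher number from compound 3 to compound 4 (0.20 log units; within the scatter). On that basis compound 4 is estimated at 11 nM, within a range from 3.5 nM to 35 nM.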

Compound 4, half-maximal inhibitory concentration: 164 nM
Estimate against measurement, compound 4: 15-fold (1.17 log units) below, and the stated range ends below it.
By their numbers in this assay, from the lowest: compound 3; then compounds 1, 2 and 4 (each within the scatter of the next).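

In this assay, among the compounds shown here, the exchange of methyl for trifluoromethyl gives the first step between compounds that differ in one place, a 24-fold higher number from compound 3 to compound 4 (1.37 log units; beyond the scatter), and it lies well beyond the scatter. The group on this aromatic carbon, para to a large group, therefore strongly affects the number in this assay, and the low value of compound 3 does not carry over to the 4-(trifluoromethyl)phenyl analogue even though the rest of the structure is unchanged. Nothing available here accounts for the size of this step.

The compounds shown leave open how a methoxy group, a chlorine atom or an amine would read at this same place. They also leave open whether this exchange would give a step of similar size on a longer chain.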